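Removing One Chloro Group: What to Expect for Compound 4

This account rests on a few compounds, and the source may have more. Where it says the series, first, only, none or still open, it means among the compounds named here.

Of the compounds shown here, three have been measured in a functional assay (Mus musculus, strain BALB/C) for inhibition, read by MTT assay, with stated times of 24 h and 72 h; a higher number here means a weaker inhibitor, a lower number a stronger inhibitor. Compound 1 `Cc1ccc(C(=O)N/N=C/c2ccc(Cl)cc2Cl)c(O)c1` gives 9780 nM, compound 2 `Cc1ccc(C(=O)N/N=C/c2ccccc2O)c(O)c1` gives 1020 nM, and compound 3 `Cc1ccc(C(=O)N/N=C/c2cc(Cl)ccc2O)c(O)c1` gives 1290 nM. Compound 1 stands well apart from the other two; how its core and the core of compound 3 differ is not broken down here. Between compound 3 and compound 2 the change is hydrogen in place of chloro on an aromatic carbon, and the step is a 1.3-fold lower number from compound 3 to compound 2 (0.10 log units; within the scatter). Compound 4 `Cc1ccc(C(=O)N/N=C/c2ccc(Cl)cc2)c(O)c1` is not yet measured and differs from compound 1 by hydrogen in place of chloro on an aromatic carbon, the same kind of change, though here the site is ortho to a large group and meta to a chloro group rather than meta to a large group and para to a hydroxy group. Compound 4 is expected to stay close to compound 1, an estimated step of a 1.2-fold lower number from compound 1 to compound 4 (0.09 log units; within the scatter), because a 1.3-fold lower number from compound 3 to compound 2 (0.10 log units; within the scatter) shows little movement. In this assay compound 4 is estimated at 8000 nM, likely between 3000 nM and 25000 nM.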

Compound 4, half-maximal inhibitory concentration: 12300 nM
Estimate against measurement, compound 4: 1.5-fold (0.19 log units) below, and the stated range covers the measured number.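

In this assay the exchange of chloro for hydrogen gives a 1.3-fold higher number from compound 1 to compound 4 (0.10 log units; within the scatter) and so leaves the number within the scatter on this core as well. Set beside the earlier step on the other core, the new step does not differ from it: the same change on two cores in this assay, a 1.3-fold lower number (0.10 log units; within the scatter) from compound 3 to compound 2 and a 1.3-fold higher number (0.10 log units; within the scatter) from compound 1 to compound 4, 1.6-fold (0.20 log units) apart, within the scatter of two such steps. This shows that the change moved the number little at these two sites on these two cores, but it does not show that the same would hold at any other site or on any other core.

Going by these compounds, what a bromo group, a methoxy group, an amine or a carboxylic acid would do in place of the chloro group stays open. What a longer chain would do in place of the methyl group of the shared core is open as well.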